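The source may hold more compounds than are shown below. What is called first, only, known or untested is meant among the compounds shown, and "the series" means these compounds.

Compound 1 (`CC(=O)Oc1ccc2c(c1)C(C)=CC(C)(C)N2Cc1ccc(C)cc1`) and compound 2 (`CC(=O)Oc1ccc2c(c1)C(C)=CC(C)(C)N2Cc1cccc(C(F)(F)F)c1`) share a core and have both been tested for cytotoxicity. In an ADME assay on L6 cells (Rattus norvegicus) for cytotoxicity, read by resazurin assay, with a stated time of 70 h (on this read-out higher numbers stand for weaker inhibition and lower numbers for stronger inhibition), compound 1 gives 21000 nM and compound 2 gives 27000 nM on the same scale. Compound 2 therefore stands within the usual scatter of compound 1, and the two numbers cannot be told apart. The next compound in the account is compound 3 (`CC(=O)Oc1ccc2c(c1)C(C)=CC(C)(C)N2Cc1cccc(C)c1`), which has methyl in place of trifluoromethyl on an aromatic carbon of compound 2, meta to a large group (methyl in place of trifluoromethyl on an aromatic carbon). Going by the values given here, no measured pair yet shows this exact change directly. Among the compounds with values here, the only guidance is that compound 1, at 21000 nM in this assay, also carries a methyl on its aromatic ring. On that basis, no change beyond the scatter is expected. The expected step is a 1.1-fold lower number from compound 2 to compound 3 (0.05 log units; within the scatter) and it is estimated to remain within the scatter. In this assay the estimate for compound 3 is 24000 nM, with an expected range from 12000 nM to 48000 nM as the likely span of the measurement.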

Compound 3, half-maximal inhibitory concentration: 28000 nM
For compound 3 the middle estimate is 1.2-fold (0.07 log units) below the measured one; low and high end bracket the measured number.
By their numbers in this assay, from the lowest: compounds 1, 2 and 3 (each within the scatter of the next).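

In this assay, the exchange at this aromatic carbon, meta to a large group, gives a 1.0-fold higher number from compound 2 to compound 3 (0.02 log units; within the scatter) and so shows that methyl in place of trifluoromethyl, a group of 1 heavy atom for one of 4 heavy atoms, leaves no difference that this read-out can resolve. Going by these compounds alone, the compounds also allow a first reading of where the methyl sits: 3-methylphenyl in place of 4-methylphenyl gives a 1.3-fold higher number from compound 1 to compound 3 (0.12 log units; within the scatter) and so leaves these two placements indistinguishable in this assay, which the earlier pair, differing in both the group and its place, could not show. No supporting measurement bears on why these numbers stay together.

As far as these compounds go, the three compounds carry only methyl or trifluoromethyl on this ring, so it remains open whether an amine, a carboxylic acid or a longer chain at this place would give a step beyond the scatter. From the compounds shown here alone, all three also keep the acetyloxy group on the shared core, and what a hydroxyl there would do to the number remains equally open.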